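This account rests on a few compounds, and the source may have more. Where it says the series, first, only, none or still open, it means among the compounds named here.

Compound 2 `COc1ccc(N2C(=O)N(Cc3c(F)cc(F)cc3OC)c3ccccc3S2(=O)=O)cc1OC` gives the lowest of the two numbers seen in an assay on isolated protein for displacement of a labelled ligand from Orexin/Hypocretin receptor type 1 (Homo sapiens), with a stated time of 90 min (a lower number here means a stronger inhibitor, a higher number a weaker inhibitor), at 63.1 nM; compound 1 `COc1ccc(N2C(=O)N(Cc3ccccc3F)c3ccccc3S2(=O)=O)cc1OC` gives 316 nM. Compound 3 `COc1ccc(N2C(=O)N(Cc3ccccc3)c3ccccc3S2(=O)=O)cc1OC` is not yet measured and differs from compound 2 by phenyl in place of 2,4-difluoro-6-methoxyphenyl on a saturated chain carbon bound to an amide-type nitrogen in a ring. Among the compounds with values here, the one step that bears on this place, a 5.0-fold lower number from compound 1 to compound 2 (0.70 log units; beyond the scatter), showed that enlarging the group on that carbon lowered the number. Stripping it back to a bare phenyl is therefore expected to raise the number in this assay, and compound 3 is estimated at 500 nM, between 160 nM and 1600 nM, which would mean a step of a 7.9-fold higher number from compound 2 to compound 3 (0.90 log units; beyond the scatter).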

Compound 3, inhibition constant: 2000 nM
Compound 3: the middle estimate sits 4.0-fold (0.60 log units) below what was measured, outside the stated range (above it).
By their numbers in this assay, from the lowest: compound 2; then compound 1; then compound 3.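

Stripping the benzyl bare costs far more in this assay than the earlier gain suggested, with a 32-fold higher number from compound 2 to compound 3 (1.50 log units; beyond the scatter) as the result. Even the lone fluoro counts, since its loss gives a 6.3-fold higher number from compound 1 to compound 3 (0.80 log units; beyond the scatter) and so compound 3 is the weakest of the three. No supporting data explain why these changes move the number. The compounds shown leave open how the second fluoro and the methoxy of compound 2 each contribute, as they appear only together. They also leave open how an amine or a carboxylic acid on this phenyl would behave.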